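From Compound 3 to Compound 4: Changing One Nitrogen Substituent

The source may hold more compounds than are shown below. What is called first, only, known or untested is meant among the compounds shown, and "the series" means these compounds.

In an ADME assay on KB cells (Homo sapiens) for cytotoxicity, with a stated time of 48 h (a higher number here means a weaker inhibitor, a lower number a stronger inhibitor), compound 3 `CC1=CCC[C@](C)(CC/C(C)=C/CC2=C(O)C(=O)C=C(N[C@@H](CO)C(=O)O)C2=O)[C@@H]1C` gives > 10 ug/mL, which is a limit of the assay and not a number. Compound 1 `CC1=CCC[C@](C)(CC/C(C)=C/CC2=C(O)C(=O)C=C(N[C@H](C(=O)O)[C@@H](C)O)C2=O)[C@@H]1C` gives > 10 ug/mL, which is also only a limit. Going by the values given here, the only measured step here is a step that the two limits leave unreadable from compound 1 to compound 3, so it offers no size to build on. Compound 2 `C=C1[C@H](C)CCC[C@]1(C)CC/C(C)=C/CC1=C(O)C(=O)C=C(N[C@@H](C(=O)O)C(C)C)C1=O` gives a real number, 6.2 ug/mL. It carries the 1-carboxy-2-methylpropyl group on its amine nitrogen, although the rest of its structure is not identical to that of compound 3.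

Compound 4 `CC1=CCC[C@](C)(CC/C(C)=C/CC2=C(O)C(=O)C=C(N[C@@H](C(=O)O)C(C)C)C2=O)[C@@H]1C` keeps the core of compound 3 and takes 1-carboxy-2-methylpropyl in place of 1-carboxy-2-hydroxyethyl on an amine nitrogen. The closest guide is compound 2 at 6.2 ug/mL, so a lower number in this assay, meaning a stronger inhibitor, is expected. The estimated step is an at least 1.6-fold lower number from compound 3 to compound 4 (0.22 log units; that floor lies within the scatter). For compound 4 the estimated value is 6 ug/mL, with an expected range of 3 ug/mL to 12 ug/mL.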

Compound 4, half-maximal inhibitory concentration: > 10 ug/mL
Compound 4: no number, only a limit (the forecaster's own chance of this, stated with the estimate: 30%); middle value at least 1.6-fold (0.22 log units) away from the limit.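

In this assay compound 4 gives > 10 ug/mL, which is a limit of the assay and not a number. The steps that reach compound 4 from compound 3 and from compound 1 therefore cannot be read. Going by these compounds alone, the only readable step is an at least 1.6-fold higher number from compound 2 to compound 4 (0.20 log units; that floor lies within the scatter): there the nitrogen substituent stays the same and the group of 9 heavy atoms on the saturated chain changes, so 1-carboxy-2-methylpropyl on the amine nitrogen does not by itself yield a measured number on the core of compound 3.

Little can be ranked among the nitrogen substituents on this core: the limit of > 10 ug/mL in this assay, at which 3 of the 4 values shown sit. As far as these compounds go, whether a longer chain or an added amine in the nitrogen substituent would give a number on this core stays open.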